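The source may hold more compounds than are shown below. What is called first, only, known or untested is meant among the compounds shown, and "the series" means these compounds.

Within the data shown here, in a physicochemical assay for lipophilicity, using the shake flask method, at pH 7.4 (a higher number here means a more lipophilic compound, a lower number a more polar compound), compound 2 (`CC(C)n1ccc2ncnc(N[C@H]3CC[C@H](N(C)C)CC3)c21`) gives 0.1, the lower of the two numbers so far, and the gap up to compound 1 (`CN(C)[C@H]1CC[C@H](Nc2ncnn3ccc(C4CCOCC4)c23)CC1`), at 0.5, lies beyond the scatter. Compound 3 (`CN(C)[C@H]1CC[C@H](Nc2ncnc3ccn(C4CCOCC4)c23)CC1`) carries oxan-4-yl in place of isopropyl on an aromatic nitrogen. Among the measured compounds shown here, the two measured compounds differ in more than one place, so no measured step shows this change directly. A moderate downward move is expected, an estimated a number 0.40 log units lower from compound 2 to compound 3 (beyond the scatter). For compound 3 the estimated value is -0.3, with an expected range from -0.8 to 0.2.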

Compound 3, distribution coefficient: -0.6
Beside the measured number, compound 3's estimate is 0.30 log units above it, and the stated range covers the measured number.
By their numbers in this assay, from the lowest: compound 3; then compound 2; then compound 1.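

Among these compounds, on an aromatic nitrogen of the five-membered aromatic ring, oxan-4-yl in place of isopropyl gives the only measured step at this position in this assay: a number 0.70 log units lower from compound 2 to compound 3 (beyond the scatter) and this lies beyond the scatter. The number falls even though the entering group has more heavy atoms, including a ring oxygen. Nothing shown gives a reason for this step. Still open, as far as these compounds go, is whether the ring or its oxygen accounts for the change. A cyclohexyl group, the same ring with carbon in place of oxygen, would separate the two.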